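The source may hold more compounds than are shown below. What is called first, only, known or untested is meant among the compounds shown, and "the series" means these compounds.

Compound 1 `CCOc1cc(CN(C)C(=O)c2c(OCCCC3CCN(C(=O)OC(C)(C)C)CC3)c3ccccc3n(C)c2=O)cc(OCC)c1`: < 0.08 ug/mL, a limit
Compound 2 `COc1cc(CN(C)C(=O)c2c(OCCCC3CCN(C(=O)OC(C)(C)C)CC3)c3cnccc3n(C)c2=O)cc(OC)c1`: 33 ug/mL
Compound 3 `CN(Cc1cc(C(F)(F)F)cc(C(F)(F)F)c1)C(=O)c1c(OCCCC2CCN(C(=O)OC3(C)CC3)CC2)c2cccnc2n(C)c1=O`: < 0.3 ug/mL, a limit

All three compounds were read in a physicochemical assay for solubility, read by LC-MS, at pH 6.8; a higher number here means a more soluble compound, a lower number a less soluble compound. Compound 3 stands at a limit, < 0.3 ug/mL, and not at a number. Compound 1 likewise gives only a limit, < 0.08 ug/mL. Only compound 2 gives a number, 33 ug/mL.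

Compound 4 `COc1cc(CN(C)C(=O)c2c(OCCCC3CCN(C(=O)OC4(C)CC4)CC3)c3cccnc3n(C)c2=O)cc(C(F)(F)F)c1` differs from compound 3 in one place, with methoxy in place of trifluoromethyl on an aromatic carbon. Among the measured compounds shown here, no measured pair shows this change alone, so the expectation is loose. A modest rise is expected in this assay, and the estimated step is an at least 2.0-fold higher number from compound 3 to compound 4 (0.30 log units; that floor lies within the scatter). Compound 4 is estimated at 0.6 ug/mL, with an expected range of 0.1 ug/mL to 4 ug/mL.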

Compound 4, solubility: 0.79 ug/mL
Estimate against measurement, compound 4: 1.3-fold (0.12 log units) below, within the range that was stated.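

Among the compounds shown here, the change of methoxy in place of trifluoromethyl, on an aromatic carbon meta to a trifluoromethyl group, is the first step here between compounds that differ in one place, and in this assay it reads an at least 2.6-fold higher number from compound 3 to compound 4 (0.42 log units; beyond the scatter). Compound 3 gives only a limit, < 0.3 ug/mL. The true size of the step therefore stays unknown, and the printed figure is only a floor, because it starts from a limit: the limit of < 0.3 ug/mL in this assay, at which 1 of the 4 values shown sits.

From the compounds shown here alone, how far the step truly reaches stays open. Also open, going by these compounds, is how an amine or a carboxylic acid would read at this same aromatic carbon, or methoxy on the remaining trifluoromethyl carbon.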